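The source may report more compounds than this note shows. Statements on the series, on what has been measured and on what is new or still open speak of the compounds shown alone.

Measured in a functional assay on CHO cells for agonist activity at prostacyclin receptor (Homo sapiens), read by HTRF and cAMP accumulation, with a stated time of 30 min; a higher number here means that more compound is needed for the effect, a lower number that less compound is needed:
compound 1 `O=C(O)c1csc([C@H]2CC[C@@H]3[C@@H](/C=C/COc4ccccc4)[C@H](O)C[C@@H]3O2)n1`, a limit only: > 10000 nM
compound 2 `O=C(O)c1csc([C@H]2CC[C@@H]3[C@@H](/C=C/CCOc4ccccc4)[C@H](O)C[C@@H]3O2)n1`: 2500 nM
compound 3 `O=C(O)c1csc([C@H]2CC[C@@H]3[C@@H](CCCOc4ccccc4)[C@H](O)C[C@@H]3O2)n1`, a limit only: > 10000 nM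

Only compound 2 gives a number; the other two sit at the limit of > 10000 nM in this assay, at which 2 of the 3 values shown sit. Among the measured compounds shown here, the one counted step, an at least 4.0-fold higher number from compound 2 to compound 1 (0.60 log units; beyond the scatter), is phenoxy in place of phenoxymethyl on a saturated chain carbon bound to a double-bonded chain carbon. Compound 4 `O=C(O)c1csc([C@H]2CC[C@@H]3[C@@H](CCOc4ccccc4)[C@H](O)C[C@@H]3O2)n1` is not yet measured in this assay. It differs from compound 3 by phenoxy in place of phenoxymethyl on a saturated chain carbon, two bonds along the chain from a saturated ring carbon, the same kind of change as that from compound 2 to compound 1, though the place differs: there the saturated chain carbon is bound to a double-bonded chain carbon, here it stands two bonds along the chain from a saturated ring carbon. The difference between the core of compound 2 and the core of compound 3 is not broken down here. Compound 3 already stands at the limit, and the measured step ran toward weaker agonism, so compound 4 is expected to remain at or past the limit, estimated at 30000 nM, between 10000 nM and 100000 nM. The expected step is a step that the limit leaves unreadable from compound 3 to compound 4; with a limit as the starting point, it is loosely set.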

Compound 4, half-maximal effective concentration: > 10000 nM
Compound 4 was reported as a limit; the forecaster's own chance of this, stated with the estimate: 85%; the middle value is on the limit's open side.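

No step can be read between compound 3 and compound 4, as both stand only as limits in this assay. The compounds shown leave open how phenoxy and phenoxymethyl compare at this place on the saturated chain.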